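The compounds below may be only part of what the source reports. "The series", "measured", "known", "first", "only" and "open" are said of these compounds alone.

Working notes on the series, assessed in a functional assay on HeLa cells (Homo sapiens) for cytotoxicity, with a stated time of 72 h; a higher number here means a weaker inhibitor, a lower number a stronger inhibitor.

Compound 1 `Clc1ccc(Cc2nn3c(Br)c(-c4ccc(Cl)cc4)nc3s2)cc1` is the bromo member of the core that bears a 4-chlorophenyl group. In this assay compound 1 gives only a limit, > 250000 nM, not a number. Compound 3 `O=Cc1c(-c2ccc(Cl)cc2)nc2sc(Cc3ccc(Cl)cc3)nn12` carries the change (formyl in place of bromo on an aromatic carbon), and in this assay compound 3 gives 16000 nM. The step of an at least 15-fold lower number from compound 1 to compound 3 (1.19 log units; beyond the scatter) is a large one, and it is stated only as a bound because the limit of > 250000 nM in this assay, at which 1 of the 3 values shown sits, fixes the starting value.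

Compound 2 `O=c1oc2ccccc2cc1-c1nc2sc(Cc3ccc(Cl)cc3)nn2c1Br` differs from compound 1 in its core; the difference between the two cores is not broken down here. In this assay, within the data shown here, compound 2 gives 4500 nM, the lowest of the two numbers measured so far, with compound 3 sitting at a higher number beyond the scatter.

Compound 4 `O=Cc1c(-c2cc3ccccc3oc2=O)nc2sc(Cc3ccc(Cl)cc3)nn12` is not yet measured. Relative to compound 2 it carries the change (formyl in place of bromo on an aromatic carbon). Among the measured compounds shown here, this is the same kind of change as the one from compound 1 to compound 3, the surroundings differing only in that the neighbouring ring atom bears a large group in the one case and a 4-chlorophenyl group in the other. For the measured compounds named here, as compound 2 already starts from a number rather than a limit, a smaller step than the one from compound 1 to compound 3 is expected, estimated as a 3.8-fold lower number from compound 2 to compound 4 (0.57 log units; beyond the scatter). For compound 4 the expected value in this assay is 1200 nM, within 300 nM to 5000 nM.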

Compound 4, half-maximal inhibitory concentration: 900 nM
Compound 4: middle estimate off by 1.3-fold (0.12 log units), on the high side; low and high end bracket the measured number.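

In this assay, formyl in place of bromo on an aromatic carbon again goes with a lower number, a 5.0-fold lower number from compound 2 to compound 4 (0.70 log units; beyond the scatter), so the direction of the change holds on both cores shown, with no pair here going against it. The size of the change does not carry over unaltered, and the two steps differ: the same change on two cores in this assay, an at least 15-fold lower number (1.19 log units; beyond the scatter) from compound 1 to compound 3 and a 5.0-fold lower number (0.70 log units; beyond the scatter) from compound 2 to compound 4, at least 3.1-fold (0.49 log units) apart, beyond the scatter of two such steps. Compound 1 gives a limit and not a number, so the earlier step and the gap between the two steps are known only as bounds, and two cores cannot show what sets that gap or whether the lower number would return on a third core: the limit of > 250000 nM in this assay, at which 1 of the 4 values shown sits.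

The compounds shown have only bromo and formyl on this aromatic carbon of the five-membered aromatic ring, so it remains open how a carboxylic acid, a nitrile or an aminomethyl group there would read, and whether the formyl itself is needed for the lower number. Also open, on these data alone, is whether the change reads the same way in cells other than HeLa, since every number here comes from that single cytotoxicity read-out.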